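This account rests on a few compounds, and the source may have more. Where it says the series, first, only, none or still open, it means among the compounds named here.

Compound 3 `CNC(=O)c1c(O)ccc2cc(-c3cccc(O)c3)ccc12` carries a methylcarbamoyl group on the shared core, and in an in vitro assay on Sf9 cells for inhibition of 17-beta-hydroxysteroid dehydrogenase type 1 (Homo sapiens), tested at 100 nM (on this read-out lower numbers stand for a weaker effect and higher numbers for a stronger effect at the one concentration tested), compound 3 gives 22%. Going by the values given here, only one other compound in this set has a number: compound 1 `O=C(c1c(O)ccc2cc(-c3cccc(O)c3)ccc12)N1CCCCC1`, with piperidin-1-yl on the carbonyl carbon, which in this assay gives 29%. The step between them, a number 7 percentage points lower from compound 1 to compound 3 (within the scatter), lies within the scatter, so the two values cannot be told apart. Compound 2 `Cc1nnc(NC(=O)c2c(O)ccc3cc(-c4cccc(O)c4)ccc23)s1` has no single number: in this assay compound 2 gives "not determined" (no result reported).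

Compound 4 `O=C(Nc1ccccc1)c1c(O)ccc2cc(-c3cccc(O)c3)ccc12` differs from compound 3 by phenyl in place of methyl on an amide-type nitrogen. Among the compounds with values here, the only measured step that touches the amide-type nitrogen is a number 7 percentage points lower from compound 1 to compound 3 (within the scatter), and it shows that exchanging one substituent for another there left the read-out unchanged within the scatter. Within the data shown here, no measured step covers the entry of a six-membered aromatic ring of carbon only at this place, so the expectation rests on that single step alone.

Compound 4 is therefore expected to behave much like compound 3, with a step of a number 6 percentage points higher from compound 3 to compound 4 (within the scatter) that need not exceed the scatter. The estimate for compound 4 in this assay is 28%, with a range from 10% to 50%.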

Compound 4, a percentage reported as inhibition, at one concentration (the size of the read-out at that concentration, not a potency): 40%
Compound 4: the middle estimate sits 12 percentage points below what was measured; the range from low to high includes it.
By their numbers in this assay, from the lowest: compounds 3 and 1 (each within the scatter of the next); then compound 4.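

In this assay, going by these compounds alone, phenyl in place of methyl on the amide-type nitrogen gives a number 18 percentage points higher from compound 3 to compound 4 (beyond the scatter), the first step at this position to exceed the scatter, so what the nitrogen carries can change the read-out. Anilino in place of piperidin-1-yl on the carbonyl carbon gives a number 11 percentage points higher from compound 1 to compound 4 (beyond the scatter), so compound 4 stands clear of both earlier compounds, and the ring of piperidin-1-yl in compound 1 had brought no such separation from compound 3. Nothing in the available evidence accounts for these steps.

Steps involving compound 2 cannot be read, and with one concentration tested, the compounds shown say nothing of potency. They also leave open whether the higher number depends on phenyl sitting directly on the nitrogen or would persist with benzyl, a longer chain ending in the same ring, or with a carboxylic acid or an amine on that ring.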